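Swapping a Sulfonamide for a Pyridine Ring

The compounds below may be only part of what the source reports. "The series", "measured", "known", "first", "only" and "open" are said of these compounds alone.

For the measured compounds named here, compound 1 `CCCCN(c1nc2c(NS(C)(=O)=O)cccc2o1)[C@H](C)c1ccc(-c2ccccc2-c2nnn[nH]2)cc1` stands highest of the two numbers so far in an ADME assay on the whole organism (Macaca fascicularis) for metabolic stability, read by LC-MS, using cassette dosing, at a dose of 1 mg/kg by the oral route (on this read-out higher numbers stand for a longer-lived compound and lower numbers for a shorter-lived compound), where compound 1 gives 4.7 h. Compound 2 `CCCCN(c1nc2c(C(=O)O)cccc2o1)[C@H](C)c1ccc(-c2cc(Cl)ccc2-c2nc(=O)o[nH]2)cc1` gives 2 h in this assay, a gap beyond the usual scatter. Compound 3 `CCCCN(c1nc2c(-c3ccccn3)cccc2o1)[C@H](C)c1ccc(-c2ccccc2-c2nnn[nH]2)cc1` differs from compound 1 in one place: pyridin-2-yl in place of methanesulfonamido on an aromatic carbon. Going by the values given here, no measured pair shows this exact change, so its size is unknown from the data. The step of a 1.2-fold lower number from compound 1 to compound 3 (0.07 log units; within the scatter) is expected to be small, within the scatter, with no clear direction. Compound 3 is therefore estimated at 4 h in this assay, with a range from 1.5 h to 10 h.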

Compound 3, half-life: 5.9 h
The estimate for compound 3 lay 1.5-fold (0.17 log units) below the measured number; the range from low to high includes it.
By their numbers in this assay, from the lowest: compound 2; then compounds 1 and 3 (each within the scatter of the next).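

In this assay, the step of a 1.3-fold higher number from compound 1 to compound 3 (0.10 log units; within the scatter) shows that this aromatic carbon can carry pyridin-2-yl in place of methanesulfonamido with no change beyond the scatter. The two groups differ considerably: one brings a six-membered aromatic ring and no hydrogen-bond donor, while the other has no ring and one donor. Nothing available explains this result.

As far as these compounds go, whether an amine, a phenyl ring or pyridin-3-yl on the same carbon would give a similar half-life remains open. So does whether any such group would keep this half-life with a different group in place of the tetrazole.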